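The source may hold more compounds than are shown below. What is called first, only, known or untested is meant among the compounds shown, and "the series" means these compounds.

Compound 1 `Cc1nc(-c2ccc(F)cc2)c(C(=O)N2CCN(c3cccc(Cl)c3)CC2)o1` stands alone with a numerical result: in a functional assay on HL-60 cells (Homo sapiens) for inhibition, read by MTT assay, with a stated time of 72 h (on this read-out lower numbers stand for stronger inhibition and higher numbers for weaker inhibition), compound 1 gives 40.1 nM. Compound 2 `COc1ccc(-c2nc(C)oc2C(=O)N2CCN(c3cccc(Cl)c3)CC2)cc1O` differs from compound 1 in more than one place. In this assay compound 2 is reported as "not active" (no number reported), with no number attached. Compound 3 `COc1cccc(N2CCN(C(=O)c3oc(C)nc3-c3ccc(F)cc3)CC2)c1` differs from compound 1 in a single place: methoxy in place of chloro on an aromatic carbon. Going by the values given here, no step between measured compounds is available, so the expectation for the move from compound 1 to compound 3 in this assay is a modest shift toward weaker inhibition, a 2.0-fold higher number from compound 1 to compound 3 (0.30 log units; within the scatter), possibly still within the scatter. For compound 3 in this assay the estimated value is 80 nM, within a range from 25 nM to 300 nM.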

Compound 3, half-maximal inhibitory concentration: 112 nM
Estimate against measurement, compound 3: 1.4-fold (0.15 log units) below, and the stated range covers the measured number.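

Replacing 3-chlorophenyl with 3-methoxyphenyl gives in this assay a 2.8-fold higher number from compound 1 to compound 3 (0.45 log units; beyond the scatter), a modest loss that goes beyond the usual scatter. The chloro group is therefore not essential for activity in these cells, since compound 3 still gives 112 nM with methoxy in its place. Nothing shown here explains why the number rises. Going by these compounds, whether an amine or a carboxylic acid at this same place would keep, lose or improve inhibition remains open. So does whether methoxy would behave the same way elsewhere on this ring.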